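The compounds below may be only part of what the source reports. "The series", "measured", "known", "first", "only" and "open" are said of these compounds alone.

Working notes on the series. For the measured compounds named here, compound 2 `COc1cc2nc(/C=C/c3ccc(F)cc3)nc(N3CCC(CCNS(N)(=O)=O)CC3)c2cc1OC` stands highest of the two numbers so far: in an assay on cells for inhibition of Ectonucleotide pyrophosphatase/phosphodiesterase family member 1 (Homo sapiens), with a stated time of 60 min, tested at 1 uM (a lower number here means less inhibition, a higher number more inhibition at the concentration tested (going by the name of the read-out)), compound 2 gives 70%. Going by the values given here, its nearest neighbour is compound 1 `COc1cc2nc(/C=C/c3cccc(F)c3)nc(N3CCC(CCNS(N)(=O)=O)CC3)c2cc1OC`, which in this assay gives 14%, so that the single measured step, 4-fluorophenyl in place of 3-fluorophenyl on a double-bonded chain carbon bound to a double-bonded chain carbon, reads a number 56 percentage points higher from compound 1 to compound 2 (beyond the scatter).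

Compound 3 `COc1ccccc1/C=C/c1nc(N2CCC(CCNS(N)(=O)=O)CC2)c2cc(OC)c(OC)cc2n1` is not yet measured. Relative to compound 2 it carries 2-methoxyphenyl in place of 4-fluorophenyl on a double-bonded chain carbon bound to a double-bonded chain carbon.

Among the compounds with values here, only the step from compound 1 to compound 2 bears on this change, and it does so indirectly: it shows that exchanging one substituted phenyl for another on the same chain carbon moved this assay by a large amount, and that of the two phenyls seen so far only the 4-fluorophenyl gave a high number. Nothing measured speaks to a 2-methoxyphenyl. The expectation is therefore a step downward for compound 3, of uncertain size, so a number 35 percentage points lower from compound 2 to compound 3 (beyond the scatter) is taken as the estimate. For compound 3 the expected value in this assay is 35%, with a range from 5% to 70%.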

Compound 3, a percentage reported as inhibition, at one concentration (the size of the read-out at that concentration, not a potency): 74%
Estimate against measurement, compound 3: 39 percentage points below; the whole stated range lies below it.
By their numbers in this assay, from the lowest: compound 1; then compounds 2 and 3 (each within the scatter of the next).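

At the place on a double-bonded chain carbon bound to a double-bonded chain carbon, this assay gives a number 4 percentage points higher from compound 2 to compound 3 (within the scatter) when 2-methoxyphenyl replaces 4-fluorophenyl, so a high number here is no longer tied to 4-fluorophenyl alone: two different substituted phenyls, with different heavy-atom counts and one carrying a hydrogen-bond acceptor that the other lacks, now read alike. The second new step, a number 60 percentage points higher from compound 1 to compound 3 (beyond the scatter) for 2-methoxyphenyl in place of 3-fluorophenyl, sets compound 1 apart from both of the others, so among these three compounds the 3-fluorophenyl is the only group that goes with a low number, and a high number at this place now goes with more than one group, which the single earlier step could not show. Nothing available explains why these phenyl groups read as they do.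

The three compounds do not separate the effect of the substituent's identity from that of where it sits on the phenyl, and they give no reference reading for an unsubstituted phenyl. As far as these compounds go, a phenyl carrying an amine or a carboxylic acid also remains open, and each of these readings rests on a single concentration.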